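A few compounds are considered here, and "the series" means these few. Any claim that something is new, unique, unknown or untested is made for them only; others in the source may bear on it.

Compound 1 `COC(c1cc(Cl)c2c(c1Cl)C(=O)N(Cc1c(C)cc(C)[nH]c1=O)CC2)C1CCS(=O)(=O)CC1` and compound 2 `Cc1cc(C)c(CN2CCc3c(Cl)cc([C@@H](CO)[C@@H]4CCOC4)c(Cl)c3C2=O)c(=O)[nH]1` share one core. In an ADME assay on microsomes from liver (Homo sapiens) for metabolic stability, read by LC-MS, using NADPH, with stated times of 10 min and 45 min, tested at 1 uM (a higher number here means faster removal of the compound, a lower number slower removal), compound 1 gives 15 uL/min; 40 uL/min (2 entries) and compound 2 gives 25.3 uL/min; the repeats of compound 1 the several entries of compound 1 in this assay, 15 uL/min; 40 uL/min (2 entries) show how far two runs can lie apart. Compound 2, with the only single number shown, sits in the same range as compound 1. Compound 3 `Cc1cc(C)c(CN2CCc3c(Cl)cc([C@@H](CO)[C@@H]4CCCO4)c(Cl)c3C2=O)c(=O)[nH]1` is not yet measured; it differs from compound 2 by oxolan-2-yl in place of oxolan-3-yl on a saturated chain carbon bound to an aromatic carbon and a saturated chain carbon. Within the data shown here, with no measured step of this kind, the expected step of a 1.0-fold lower number from compound 2 to compound 3 (0.01 log units; within the scatter) in this assay is none beyond the scatter. For compound 3 the estimate is 25 uL/min, from 12 uL/min to 50 uL/min.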

Compound 3, intrinsic clearance in a liver preparation (reported as CLH), per the amount of preparation that the assay uses: 70.3 uL/min
Compound 3: middle estimate off by 2.8-fold (0.45 log units), on the low side; measured number above the stated range.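

In this assay, oxolan-2-yl in place of oxolan-3-yl gives a 2.8-fold higher number from compound 2 to compound 3 (0.44 log units; beyond the scatter) with the same atoms, so the point of attachment alone counts at this saturated chain carbon. This is the only measured step at this position, and it rests on a single pair, while repeat runs of one compound can lie well apart: the several entries of compound 1 in this assay, 15 uL/min; 40 uL/min (2 entries)

The compounds shown leave open how an amine or a longer chain on this carbon would read in this assay. They also leave open whether the opposite configuration of the oxolan-2-yl ring would keep the higher number.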